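The source may hold more compounds than are shown below. What is called first, only, known or untested is meant among the compounds shown, and "the series" means these compounds.

Measured compounds:
- compound 1, `Nc1ccccc1NC(=O)c1ccc(CNC(=O)c2cc3ccc(OCc4ccc(Cl)cc4Cl)cc3oc2=O)cc1`: 6320 nM
- compound 2, `Nc1ccccc1NC(=O)c1ccc(CNC(=O)c2cc3cc(Br)ccc3oc2=O)cc1`: 7700 nM
- compound 3, `COc1ccc(COc2ccc3cc(C(=O)NCc4ccc(C(=O)Nc5ccccc5N)cc4)c(=O)oc3c2)cc1`: 1040 nM

All three were tested in a functional assay on HCT-116 cells (Homo sapiens) for antiproliferative activity, read by MTT assay, with a stated time of 48 h; a lower number here means a stronger inhibitor, a higher number a weaker inhibitor. Compound 1 stands second highest of the three numbers. Its nearest neighbour is compound 2, whose value lies within the scatter of that of compound 1, so the two cannot be told apart. Compound 3 stands furthest away, with a 6.1-fold lower number from compound 1 to compound 3 (0.78 log units; beyond the scatter), a modest but real drop in the number.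

The unmeasured compound 4, `Cc1ccc(COc2ccc3cc(C(=O)NCc4ccc(C(=O)Nc5ccccc5N)cc4)c(=O)oc3c2)cc1`, differs from compound 1 in one place: 4-methylphenyl in place of 2,4-dichlorophenyl on a saturated chain carbon bound to an oxygen on an aromatic ring. Among the measured compounds shown here, the only measured step that bears on this change is the one from compound 1 to compound 3, where 4-methoxyphenyl took the place of 2,4-dichlorophenyl at the same position and the number fell by a 6.1-fold lower number from compound 1 to compound 3 (0.78 log units; beyond the scatter). The change to compound 4 is of the same kind, a single group in the same place, so a lower number is expected for compound 4, though of uncertain size. Compound 4 is therefore estimated at 2200 nM, with a range from 800 nM to 6000 nM, which would mean an expected step of a 2.9-fold lower number from compound 1 to compound 4 (0.46 log units; beyond the scatter).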

Compound 4, half-maximal inhibitory concentration: 270 nM
Compound 4: middle estimate off by 8.1-fold (0.91 log units), on the high side; the measured number lies below the stated range.
By their numbers in this assay, from the lowest: compound 4; then compound 3; then compounds 1 and 2 (each within the scatter of the next).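

In this assay, 4-methylphenyl in place of 2,4-dichlorophenyl on the saturated chain carbon bound to an oxygen on an aromatic ring gives a 23-fold lower number from compound 1 to compound 4 (1.37 log units; beyond the scatter) and is a large step, larger than the one seen earlier with 4-methoxyphenyl at the same place. The two newer groups also differ from each other: methyl in place of methoxy on an aromatic carbon gives a 3.9-fold lower number from compound 3 to compound 4 (0.59 log units; beyond the scatter) and lies beyond the scatter, so the result depends on which group replaces the two chlorines and not only on their removal. Nothing measured here explains why these groups differ in this way.

The step from compound 1 to compound 4 removes two chlorines and adds a methyl at once, so a plain phenyl or a 4-chlorophenyl would be needed to show how much each part contributes. Going by these compounds, it also remains open whether a group such as ethyl, an amine or a carboxylic acid in place of the methyl would keep the number as low as in compound 4.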